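Amide nitrogen substituent: aryl to cyclopentyl, clearance outlook

The source may report more compounds than this note shows. Statements on the series, on what has been measured and on what is new or still open speak of the compounds shown alone.

Going by the values given here, compound 3 `Cc1cc(NC(=O)[C@H]2CN(C)C[C@@H]2c2ccc(/C=C/C(=O)Nc3ccccc3N)cc2)ccc1Cl` stands highest of the three numbers so far in an in vitro ADME assay on microsomes from liver (Mus musculus) for pharmacokinetics, read by LC-MS, with a stated time of 10 min, tested at 1 uM (a higher number here means faster removal of the compound, a lower number slower removal), where compound 3 gives 65 mL/min/kg, though within the scatter of both neighbours. Compound 1 `COc1ccc(NC(=O)[C@H]2CN(C)C[C@@H]2c2ccc(/C=C/C(=O)Nc3ccccc3N)cc2)cc1` gives 54 mL/min/kg and compound 2 `CN1C[C@H](C(=O)Nc2ccc(F)c(Cl)c2)[C@@H](c2ccc(/C=C/C(=O)Nc3ccccc3N)cc2)C1` gives 34 mL/min/kg; the steps of a 1.6-fold lower number from compound 1 to compound 2 (0.20 log units; within the scatter), a 1.2-fold higher number from compound 1 to compound 3 (0.08 log units; within the scatter) and a 1.9-fold higher number from compound 2 to compound 3 (0.28 log units; within the scatter) all lie within the scatter. Compound 4 `CN1C[C@H](C(=O)NC2CCCC2)[C@@H](c2ccc(/C=C/C(=O)Nc3ccccc3N)cc2)C1` takes the next step: cyclopentyl in place of 4-chloro-3-methylphenyl on an amide-type nitrogen. Among the compounds with values here, no measured step exchanges an aromatic ring for a non-aromatic one on this nitrogen, so the three aryl-to-aryl steps bear only loosely on it; since each stayed within the scatter, no step beyond the scatter is expected for a 1.2-fold lower number from compound 3 to compound 4 (0.07 log units; within the scatter). Compound 4 is estimated at 55 mL/min/kg, with a range from 28 mL/min/kg to 110 mL/min/kg.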

Compound 4, clearance: 61 mL/min/kg
For compound 4 the middle estimate is 1.1-fold (0.04 log units) below the measured one, and the stated range covers the measured number.
By their numbers in this assay, from the lowest: compounds 2, 1, 4 and 3 (each within the scatter of the next).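

On the amide-type nitrogen, cyclopentyl now stands where only aryl groups stood, and in this assay the exchange of an aromatic ring for a non-aromatic one stays within the scatter against all three aryl groups: a 1.1-fold lower number from compound 3 to compound 4 (0.03 log units; within the scatter) and a 1.8-fold higher number from compound 2 to compound 4 (0.25 log units; within the scatter) and a 1.1-fold higher number from compound 1 to compound 4 (0.05 log units; within the scatter). Clearance in these four compounds therefore does not separate cyclopentyl from the aryl groups. No measured evidence explains this result. Still open, on these data alone, is whether an aminoethyl chain or a carboxylic acid on this nitrogen would give a step beyond the scatter. As far as these compounds go, whether the same holds outside mouse liver microsomes also remains open.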